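Chloro to Fluoro on a Dioxygenase Series

A few compounds are considered here, and "the series" means these few. Any claim that something is new, unique, unknown or untested is made for them only; others in the source may bear on it.

Compound 1 `CC(C)C(=O)N1CCc2cc(CNC(=O)c3ccc(Cl)cc3)ccc21`: 92%
Compound 2 `CCC(=O)NCc1ccc2c(c1)CCN2C(=O)c1ccccc1`: 41%

Both compounds were tested in an assay on HEK293 cells for inhibition of Indoleamine 2,3-dioxygenase 1 (Homo sapiens), tested at 10 uM; a higher number here means more inhibition at the concentration tested (going by the name of the read-out), a lower number less inhibition. Compound 1 gives the higher of the two numbers, and compound 2 sits well below it, beyond the usual scatter of this kind of measurement.

Compound 3 `CC(C)C(=O)N1CCc2cc(CNC(=O)c3ccc(F)cc3)ccc21` differs from compound 1 by fluoro in place of chloro on an aromatic carbon. Among the measured compounds shown here, no measured pair shows this change, so the expectation rests on compound 1 alone: a modest drop is expected, partly because compound 1 at 92% leaves little room to rise. Compound 3 is expected to give 76%, with a range from 50% to 92%. The expected step is a number 16 percentage points lower from compound 1 to compound 3 (beyond the scatter).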

Compound 3, a percentage reported as inhibition, at one concentration (the size of the read-out at that concentration, not a potency): 88%
The estimate for compound 3 lay 12 percentage points below the measured number, within the range that was stated.
By their numbers in this assay, from the lowest: compound 2; then compounds 3 and 1 (each within the scatter of the next).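

In this assay, changing 4-chlorophenyl to 4-fluorophenyl gives a number 4 percentage points lower from compound 1 to compound 3 (within the scatter), so at this position chloro is not required for a high reading; fluoro serves as well. Both readings come from a single concentration, so they do not show whether the two compounds match in potency. Nothing measured here explains why the two halogens read alike. Still open, as far as these compounds go, is whether an amine, a methoxy group or a carboxylic acid on this aromatic carbon would hold the reading. Equally open, from the compounds shown here alone, is what a bare hydrogen there would do.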